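Trimming a hydroxyethyl chain down to methyl

The compounds below may be only part of what the source reports. "The series", "measured", "known", "first", "only" and "open" are said of these compounds alone.

Compound 1 `O=C(O)c1[nH]cc(C(=O)NCc2ccc(F)cc2)c(=O)c1O`: > 200000 nM, a limit
Compound 2 `COCCNC(=O)c1[nH]cc(C(=O)NCc2ccc(F)cc2)c(=O)c1O`: 16000 nM
Compound 3 `O=C(NCCO)c1[nH]cc(C(=O)NCc2ccc(F)cc2)c(=O)c1O`: > 200000 nM, a limit

In an ADME assay on MT4 cells (Homo sapiens) for cytotoxicity, read by MTT assay, with a stated time of 4 days (a lower number here means that less compound is tolerated, a higher number that more compound is tolerated), compound 3 stands at > 200000 nM, which is a limit and not a number. Compound 4 `CNC(=O)c1[nH]cc(C(=O)NCc2ccc(F)cc2)c(=O)c1O` carries methylamino where compound 3 has (2-hydroxyethyl)amino (hydrogen in place of hydroxymethyl on a saturated chain carbon bound to an amide-type nitrogen). Like compound 2, compound 4 has no free hydroxy on its chain. The main guide is therefore an at least 12-fold higher number from compound 2 to compound 3 (1.09 log units; beyond the scatter), read in reverse. A second guide is an at least 12-fold lower number from compound 1 to compound 2 (1.09 log units; beyond the scatter). Going by the values given here, both steps are large, though only two compounds with such chains can be compared. The expected change is an at least 4.0-fold lower number from compound 3 to compound 4 (0.60 log units; beyond the scatter), towards a lower number in this assay. For compound 4 the estimated value is 50000 nM, with an expected range from 12000 nM to 200000 nM.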

Compound 4, half-maximal cytotoxic concentration: 8500 nM
Compound 4: middle estimate off by 5.9-fold (0.77 log units), on the high side; measured number outside the range, below it.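

In this assay, the hydroxy on the chain proves to be what separates compound 3 from the others with an amide chain: trimming to methyl gives an at least 23-fold lower number from compound 3 to compound 4 (1.37 log units; beyond the scatter), while the step from the capped chain gives a 1.9-fold lower number from compound 2 to compound 4 (0.27 log units; within the scatter), so the methyl and 2-methoxyethyl chains read alike. Methylamino in place of hydroxy on the carbonyl carbon likewise gives an at least 23-fold lower number from compound 1 to compound 4 (1.37 log units; beyond the scatter). Compound 1 and compound 3 each stand at a limit, so the true size of these two large steps stays unknown: the limit of > 200000 nM in this assay, at which 2 of the 4 values shown sit.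

On these data alone, it remains open whether a longer chain ending in an amine or a carboxylic acid would behave like compound 3 or like compound 4.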